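Shortening the Chain: From Compound 3 to Compound 4

This account rests on a few compounds, and the source may have more. Where it says the series, first, only, none or still open, it means among the compounds named here.

Of the compounds shown here, three sharing one core have been tested in an assay on HEK293 cells for inhibition of solute carrier family 12 member 2 (Homo sapiens), read by fluorescence, with a stated time of 30 min, tested at 100 uM; on this read-out higher numbers stand for a stronger effect at the one concentration tested and lower numbers for a weaker effect. Compound 1 `CCCCCCNc1ccc(C(=O)O)cc1S(=O)(=O)N(C)C` gives 19.8%, compound 2 `CCCCCCCCNc1ccc(C(=O)O)cc1S(=O)(=O)N(C)C` gives 70.6%, and compound 3 `CN(C)S(=O)(=O)c1cc(C(=O)O)ccc1NCCCCCC(F)(F)F` gives 12.6%. Compound 3 stands lowest of the three, though its gap to compound 1 lies within the scatter, while compound 2 sits far above it.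

Compound 4 `COCCNc1ccc(C(=O)O)cc1S(=O)(=O)N(C)C` differs from compound 3 in one place: methoxy in place of 4,4,4-trifluorobutyl on a saturated chain carbon, two bonds along the chain from a nitrogen on an aromatic ring. The chain on the ring nitrogen thus becomes much shorter. The measured steps speak to chain length. Lengthening the chain gave a number 50.8 percentage points higher from compound 1 to compound 2 (beyond the scatter), and moving from the longer plain chain to the fluorinated one gave a number 58 percentage points lower from compound 2 to compound 3 (beyond the scatter), whereas a number 7.2 percentage points lower from compound 1 to compound 3 (within the scatter) was small. A weak read-out is expected for compound 4 because a number 50.8 percentage points higher from compound 1 to compound 2 (beyond the scatter) ran upward with a longer chain, and compound 4 carries the shortest chain of the set. The expected step of a number 4.6 percentage points lower from compound 3 to compound 4 (within the scatter) should stay within the scatter. Compound 4 is estimated at 8%, within a range from 0% to 25%.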

Compound 4, a percentage reported as inhibition, at one concentration (the size of the read-out at that concentration, not a potency): 4.1%
Beside the measured number, compound 4's estimate is 3.9 percentage points above it; the range from low to high includes it.
By their numbers in this assay, from the lowest: compounds 4, 3 and 1 (each within the scatter of the next, the first and the last beyond it); then compound 2.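

Replacing 4,4,4-trifluorobutyl with methoxy at this position leaves the read-out within the scatter (a number 8.5 percentage points lower from compound 3 to compound 4 (within the scatter)), so this large change in the group does not separate compound 3 from compound 4. The comparison with the plain chains is clearer: methoxy in place of butyl gives the first drop below compound 1 that lies beyond the scatter (a number 15.7 percentage points lower from compound 1 to compound 4 (beyond the scatter)), and methoxy in place of hexyl gives a much larger one (a number 66.5 percentage points lower from compound 2 to compound 4 (beyond the scatter)). Nothing available here explains these steps.

Compound 4 shortens the chain and brings in an oxygen in the same change, so the effects of length and oxygen remain tangled; a plain propyl chain would help to pull them apart. Also open, as far as these compounds go, is how an amine or a carboxylic acid at the end of a chain as long as that of compound 2 would read out, and whether a still longer chain would rise further.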